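Cyclobutyl to 4-hydroxycyclohexyl on the amide nitrogen

This account rests on a few compounds, and the source may have more. Where it says the series, first, only, none or still open, it means among the compounds named here.

The series shares the core of compound 1 (`Nc1sc(-c2ccc(Cl)cc2)c(-c2ccc(Cl)cc2)c1C(=O)N1CCCCC1=O`) and varies the group on the carbonyl carbon. In a functional assay on A549 cells (Homo sapiens) for inhibition, read by sulforhodamine B assay, with a stated time of 72 h (a higher number here means a weaker inhibitor, a lower number a stronger inhibitor), compound 1 gives 1820 nM, and compound 2 (`CC1CN(C(=O)c2c(N)sc(-c3ccc(Cl)cc3)c2-c2ccc(Cl)cc2)CCN1`) gives 4930 nM. Compound 3 (`Nc1sc(-c2ccc(Cl)cc2)c(-c2ccc(Cl)cc2)c1C(=O)NC1CCC1`) gives 12500 nM, the highest of the three numbers, which makes it the weakest inhibitor of this small set.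

The next entry is compound 4 (`Nc1sc(-c2ccc(Cl)cc2)c(-c2ccc(Cl)cc2)c1C(=O)NC1CCC(O)CC1`), with 4-hydroxycyclohexyl in place of cyclobutyl on an amide-type nitrogen. For the measured compounds named here, no measured step makes this exact change. The closest evidence is a 6.9-fold higher number from compound 1 to compound 3 (0.84 log units; beyond the scatter) and a 2.5-fold higher number from compound 2 to compound 3 (0.40 log units; beyond the scatter), both modest and beyond the scatter. These steps show that the number in this assay responds to the group on the carbonyl carbon, but neither isolates ring size or the hydroxyl. With compound 3 already at 12500 nM, the top of the measured range, a modest move towards a lower number is the more likely outcome, although a result within the scatter remains possible. The expected size of the change is a 1.8-fold lower number from compound 3 to compound 4 (0.25 log units; within the scatter). For compound 4 the estimated value is 7000 nM, with an expected range of 2500 nM to 18000 nM.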

Compound 4, half-maximal inhibitory concentration: 250 nM
Compound 4: the middle estimate sits 28-fold (1.45 log units) above what was measured, and the stated range ends above it.
By their numbers in this assay, from the lowest: compound 4; then compound 1; then compound 2; then compound 3.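

In this assay, for the compounds shown here, the group on the amide-type nitrogen moves the number far more than the earlier steps suggested: a 50-fold lower number from compound 3 to compound 4 (1.70 log units; beyond the scatter) is larger than any step among the three earlier compounds. The (4-hydroxycyclohexyl)amino group also outperforms both groups joined through a ring nitrogen, with a 20-fold lower number from compound 2 to compound 4 (1.29 log units; beyond the scatter) and a 7.3-fold lower number from compound 1 to compound 4 (0.86 log units; beyond the scatter), making compound 4 the strongest inhibitor of the four. Compound 3 and compound 4 are both joined through an amide-type nitrogen yet stand at opposite ends of the order, so this attachment alone does not set the number here, and no measurement bearing on the reason for the size of this change is available.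

The change from cyclobutyl to 4-hydroxycyclohexyl enlarges the ring and adds the hydroxyl at once, and the compounds shown leave open how the step divides between the two. An unsubstituted cyclohexyl on the same nitrogen would separate those two changes, while a 4-aminocyclohexyl or 4-methoxycyclohexyl group would show whether the hydroxyl itself is needed or another group at that place serves as well.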